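The source may hold more compounds than are shown below. What is called first, only, known or untested is meant among the compounds shown, and "the series" means these compounds.

Compounds measured so far in an assay on isolated protein for inhibition of microsomal triglyceride transfer protein large subunit (Homo sapiens); on this read-out lower numbers stand for stronger inhibition and higher numbers for weaker inhibition:

compound 1, `Cc1cccc(C(=O)Nc2ccc3c(c2)CC(NS(=O)(=O)c2ccccc2)C3)c1-c1ccc(F)cc1`, gives 240 nM

compound 2, `Cc1cccc(C(=O)Nc2ccc3c(c2)CC(NS(=O)(=O)c2ccccc2)C3)c1-c1ccc(Cl)cc1`, gives 100 nM

compound 3, `CS(=O)(=O)NC1Cc2ccc(NC(=O)c3ccccc3-c3ccc(C(F)(F)F)cc3)cc2C1`, gives 120 nM

Compound 3 stands second highest of the three numbers in this assay. Its value sits within the scatter of both neighbours: the gap to compound 2 and the gap to compound 1 are each small enough to count as repeat-measurement noise, so no order among the three can be read from them.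

Compound 4, `CC(=O)NC1Cc2ccc(NC(=O)c3ccccc3-c3ccc(C(F)(F)F)cc3)cc2C1`, differs from compound 3 in one place: acetyl in place of methylsulfonyl on an amine nitrogen.

The only measured step among these compounds is a 2.4-fold lower number from compound 1 to compound 2 (0.38 log units; beyond the scatter), a swap of one halogen for another on an aromatic carbon. That change sits on a different part of the molecule and concerns a different kind of group, so it does not bear on replacing methylsulfonyl with acetyl on the amine nitrogen. Among the compounds with values here, no measured pair here shows what that replacement does.

Without a comparable step, the expectation for compound 4 rests on compound 3 alone: a value close to compound 3, with a wide range, is expected, corresponding to a 2.1-fold higher number from compound 3 to compound 4 (0.32 log units; beyond the scatter). The estimate for compound 4 in this assay is 250 nM, expected to fall between 80 nM and 800 nM.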

Compound 4, half-maximal inhibitory concentration: 80 nM
For compound 4 the middle estimate is 3.1-fold (0.49 log units) above the measured one; the measured number falls inside the stated range.
By their numbers in this assay, from the lowest: compounds 4, 2, 3 and 1 (each within the scatter of the next, the first and the last beyond it).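

Replacing methylsulfonyl with acetyl on the amine nitrogen gives a 1.5-fold lower number from compound 3 to compound 4 (0.18 log units; within the scatter) in this assay, so the two groups cannot be told apart on this read-out. Within the data shown here, this is the first measured step at this nitrogen, as the only earlier step was a halogen swap elsewhere on the molecule, and it shows that, in this pair, the sulfonyl group can give way to a carbonyl without a change larger than the usual scatter of repeat measurements. No supporting measurement explains why the two groups read alike, so the result stands as an observation only.

The compounds shown do not tell how a free amine, or a longer acyl chain such as butanoyl, would read on this nitrogen, so it remains open whether a sulfonyl or carbonyl group is needed there at all. Compounds 1 and 2 differ from this pair in more than one place, so it is also unknown whether the same swap would be tolerated with their phenylsulfonyl group and their substituted core.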